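The compounds below may be only part of what the source reports. "The series", "measured", "known", "first", "only" and "open" are said of these compounds alone.

Measured in a functional assay on NCI-H1975 cells (Homo sapiens) for antiproliferative activity, read by MTT assay, with a stated time of 72 h; on this read-out higher numbers stand for weaker inhibition and lower numbers for stronger inhibition:
- compound 1 `CN1CCN(c2ccc(Nc3ncc4nc(Nc5ccc(F)cc5)n([C@@H]5CCN(S(=O)(=O)C6CC6)C5)c4n3)cc2)CC1`: > 10000 nM, a limit of the assay
- compound 2 `CN1CCN(c2ccc(Nc3ncc4nc(Nc5ccc(F)cc5)n(CCNS(=O)(=O)C5CC5)c4n3)cc2)CC1`: "not determined" (no result reported)

Compound 2 has no number in this assay, so it has no place on the scale. The only other entry is also not a number, as the limit of > 10000 nM in this assay, at which 1 of the 2 values shown sits, shows. Compound 1 stays at > 10000 nM, which is a limit.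

Compound 3 `CN1CCN(c2ccc(Nc3ncc4nc(Nc5ccc(F)cc5)n([C@H]5CCN(S(=O)(=O)C6CC6)C5)c4n3)cc2)CC1` has not yet been measured. The structural change is 1-(cyclopropylsulfonyl)pyrrolidin-3-yl in place of 2-((cyclopropylsulfonyl)amino)ethyl on an aromatic nitrogen. This spot is next to the ring atom that bears a (4-fluorophenyl)amino group.

Within the data shown here, no measured step shows what such a change does, and compound 2 offers no number to start from. The size of the step from it therefore cannot be stated. The expectation rests on compound 1 alone, with its entry of > 10000 nM, and it is for weak inhibition in this assay, with a real chance that only a limit is reported again. For compound 3 the expected value is 6000 nM, with an estimated range of 1000 nM to 20000 nM.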

Compound 3, half-maximal inhibitory concentration: 580 nM
Compound 3: the middle estimate sits 10-fold (1.01 log units) above what was measured, and the stated range ends above it.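

Compound 3 shows that at this aromatic nitrogen, next to the ring atom that bears a (4-fluorophenyl)amino group, the 1-(cyclopropylsulfonyl)pyrrolidin-3-yl group is compatible with clear antiproliferative activity in this assay, but only with one drawn configuration at its saturated ring carbon, the pair giving an at least 17-fold lower number from compound 1 to compound 3 (1.23 log units; beyond the scatter). Compound 1 stands at > 10000 nM, which is a limit of the assay. The large step, beyond the scatter, can be assigned to the stereocentre alone, a point the earlier entries could not make, because the rest of the structure is unchanged, as shown by one fact: the fact that compounds 1 and 3 differ only in the configuration as drawn.

Going by these compounds, the step from compound 2 cannot be read, since that compound has no result, so how the open 2-((cyclopropylsulfonyl)amino)ethyl chain compares with either pyrrolidine ring remains unknown. Also open, on these data alone, is whether the preference for the S configuration would hold with a piperidin-3-yl ring in place of the pyrrolidine, or with a methylsulfonyl or acetyl group in place of the cyclopropylsulfonyl group.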